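The compounds below may be only part of what the source reports. "The series", "measured", "known", "first", "only" and "open" are said of these compounds alone.

In an ADME assay on BaF3 cells (Mus musculus) for antiproliferative activity, read by CCK-8 assay, with a stated time of 72 h (on this read-out higher numbers stand for weaker inhibition of growth and lower numbers for stronger inhibition of growth), compound 1 `Cc1ccc(C(=O)Nc2ccc(CN3CCN(C)CC3)c(C(F)(F)F)c2)cc1C#Cc1ncc2cccnn12` gives 940 nM. Compound 2 `COc1cccc(NC(=O)CCSc2ccc3c(/C=C/c4ccccn4)n[nH]c3c2)c1` gives 3840 nM, the higher of these two numbers, and so the weaker inhibition of growth. Compound 3 `CN1CCN(c2cccc(NC(=O)CCSc3ccc4c(/C=C/c5ccccn5)n[nH]c4c3)c2)CC1` gives > 10000 nM, which is a limit of the assay and not a number.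

Compound 4 `O=C(CCSc1ccc2c(/C=C/c3ccccn3)n[nH]c2c1)Nc1ccc(F)c(C(F)(F)F)c1` keeps the shared core of compound 2 and differs in one place: 4-fluoro-3-(trifluoromethyl)phenyl in place of 3-methoxyphenyl on an amide-type nitrogen.

Going by the values given here, only one measured step touches the same aromatic ring: an at least 2.6-fold higher number from compound 2 to compound 3 (0.41 log units; beyond the scatter), with 4-methylpiperazin-1-yl in place of methoxy, and it ends at a limit. It shows that a change on this ring can move the number beyond the scatter, but its entering group has little in common with the new one. Among the compounds with values here, the only other hint is compound 1, which also carries a trifluoromethyl group and gives 940 nM, though on a different core.

A small move toward a lower number, not clearly beyond the scatter, is therefore expected, and the estimated change is a 1.5-fold lower number from compound 2 to compound 4 (0.19 log units; within the scatter). For compound 4 the estimate is 2500 nM, with an expected range from 600 nM to 9000 nM.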

Compound 4, concentration for 50% growth inhibition: 610 nM
Estimate against measurement, compound 4: 4.1-fold (0.61 log units) above; the range from low to high includes it.
By their numbers in this assay, from the lowest: compounds 4 and 1 (each within the scatter of the next); then compound 2. At a limit, above all of these: compound 3.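

In this assay, the change on the amide-type nitrogen gives a 6.3-fold lower number from compound 2 to compound 4 (0.80 log units; beyond the scatter), which shows that a new group at this position can lower the number as well as raise it. Compound 3 stands at a limit of the assay and not at a number, so the earlier change on this ring has no full size that can be read: the limit of > 10000 nM in this assay, at which 1 of the 4 values shown sits. Compound 4 therefore gives the first change from compound 2 at this position that ends in a measured number, and it runs in the opposite direction to the change to compound 3.

The fluorine and the trifluoromethyl group enter together, and the compounds shown do not separate their shares in this step. As far as these compounds go, it also stays open how a single chlorine or a carboxylic acid on this ring would change the number.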